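The compounds below may be only part of what the source reports. "The series", "measured", "known", "first", "only" and "open" are said of these compounds alone.

Two phthalimide-free comparators open the series. Compound 1 `CSc1ccc2ccccc2n1` in a functional assay on PC-3 cells (Homo sapiens) for cytotoxicity, read by MTT assay, with a stated time of 72 h (a lower number here means a stronger inhibitor of growth, a higher number a weaker inhibitor of growth), gives 87000 nM. Compound 2 `O=C1c2ccccc2C(=O)N1CS` in this assay gives 74700 nM; the numbers of compound 2 and compound 1 lie within the scatter of each other, so neither is ranked against the other. For the measured compounds named here, no step between two measured compounds is known here, and nothing measured shares the core of compound 2. Compound 3 `N#C[Se]CN1C(=O)c2ccccc2C1=O` differs from compound 2 by a group of 3 heavy atoms (1 carbon, 1 nitrogen, 1 selenium; no ring) in place of one sulfur atom, on a saturated chain carbon bound to an amide-type nitrogen in a ring. Going by the values given here, with no matching step measured, the size of the move is set by judgement alone: a moderate step downward in this assay is expected, larger than the scatter but with wide uncertainty in both directions. The expected step from compound 2 to compound 3 is a 3.0-fold lower number from compound 2 to compound 3 (0.48 log units; beyond the scatter). Compound 3 in this assay is therefore estimated at 25000 nM, within a range from 5000 nM to 110000 nM.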

Compound 3, concentration for 50% growth inhibition: 11200 nM
For compound 3 the middle estimate is 2.2-fold (0.35 log units) above the measured one; low and high end bracket the measured number.
By their numbers in this assay, from the lowest: compound 3; then compounds 2 and 1 (each within the scatter of the next).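

In this assay, for the compounds shown here, the place on a saturated chain carbon bound to an amide-type nitrogen in a ring turns out to respond to substitution: putting the group of 3 heavy atoms (1 carbon, 1 nitrogen, 1 selenium; no ring) in place of the sulfanyl gives a 6.7-fold lower number from compound 2 to compound 3 (0.82 log units; beyond the scatter) and is the only step read so far. The change also removes the hydrogen-bond donor and adds a triple bond, and this single step cannot separate these differences from the entry of selenium. Nothing at hand bears on the reason for the step.

From the compounds shown here alone, what a thiocyanate would give at this place stays open, and with it whether the step goes with the selenium or with the triple-bonded carbon and nitrogen. Also open, going by these compounds, is whether a longer chain in place of the saturated chain carbon would preserve the step.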